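Working notes on solubility in the series, compound 4

The source may hold more compounds than are shown below. What is called first, only, known or untested is meant among the compounds shown, and "the series" means these compounds.

Compound 1 `Cc1nc(C(=O)N(C)C)c(N)c2c1C(=O)N(Cc1ccccc1)C2=O` is the member without the pyridin-4-yl bearing group; in a physicochemical assay for solubility, using the shake flask method, in simulated intestinal fluid, measured as kinetic solubility, with a stated time of 2 h, at 25 degrees C, at pH 6.5 (a lower number here means a less soluble compound, a higher number a more soluble compound), compound 1 gives 172000 nM. Compound 2 `Cc1noc(-c2nc(C)c3c(c2N)C(=O)N(Cc2ccc(-c4ccncc4)cc2)C3=O)n1` carries the shared core with a pyridin-4-yl on an aromatic carbon. In this assay compound 2 gives < 5000 nM, which is a limit of the assay and not a number. Compound 3 `Cc1noc(-c2nc(C)c3c(c2N)C(=O)N(Cc2ccc(Br)cc2)C3=O)n1` gives < 5000 nM in this assay, again a limit. The step that the two limits leave unreadable from compound 2 to compound 3 thus cannot be read, both values sitting at the limit of < 5000 nM in this assay, at which 2 of the 3 values shown sit.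

Compound 4 `Cc1noc(-c2nc(C)c3c(c2N)C(=O)N(Cc2ccc(OC(F)F)cc2)C3=O)n1` differs from compound 2 by difluoromethoxy in place of pyridin-4-yl on an aromatic carbon. Among the compounds with values here, no measured step bears directly on this change; the only step, a step that the two limits leave unreadable from compound 2 to compound 3, is itself unreadable, and the core of compound 1 differs from the others so that compound 1 forms no step with them. Compound 2 stands at a limit, and no direction beyond scatter can be expected. Compound 4 is expected to remain at the same limit, with an estimated step that the limit leaves unreadable from compound 2 to compound 4. The estimate for compound 4 in this assay is 3000 nM, ranging from 500 nM to 12000 nM.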

Compound 4, solubility: < 5000 nM
Compound 4: only a limit was reported (the forecaster's own chance of this, stated with the estimate: 70%); the middle value is on the limit's open side.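

In this assay compound 4 gives < 5000 nM, a limit of the assay and not a number. No step among compound 2, compound 3 and compound 4 can be read: the limit of < 5000 nM in this assay, at which 3 of the 4 values shown sit.

Going by these compounds, how compound 2, compound 3 and compound 4 order among themselves in this assay remains open.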